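A Second Bromine on a Phosphatase Series

The compounds below may be only part of what the source reports. "The series", "measured", "known", "first", "only" and "open" are said of these compounds alone.

Compound 1 `O=C1NC(=S)S/C1=C\C=C\c1ccccc1OCc1ccncc1`: 39.4%
Compound 2 `O=C1NC(=S)S/C1=C\C=C\c1ccccc1OCc1ccccc1`: 49.5%
Compound 3 `O=C1NC(=S)S/C1=C\C=C\c1ccccc1OCc1ccccc1Br`: 63.1%

Of the compounds shown here, three have been measured in an assay on isolated protein for inhibition of protein tyrosine phosphatase type IVA 3 (Homo sapiens), tested at 5 ug/mL; a lower number here means less inhibition, a higher number more inhibition at the concentration tested (going by the name of the read-out). Compound 3 stands highest of the three: the nearest value lies a number 13.6 percentage points higher from compound 2 to compound 3 (beyond the scatter), and the furthest lies a number 23.7 percentage points higher from compound 1 to compound 3 (beyond the scatter). Compound 4 `O=C1NC(=S)S/C1=C\C=C\c1cc(Br)ccc1OCc1ccccc1Br` differs from compound 3 by bromo in place of hydrogen on an aromatic carbon. Among the compounds with values here, only one measured step bears on this change, a number 13.6 percentage points higher from compound 2 to compound 3 (beyond the scatter), where a bromo likewise replaced a hydrogen, though on a different ring. That step was modest, and compound 3 already stands high, so a smaller rise is expected, a number 6.9 percentage points higher from compound 3 to compound 4 (within the scatter). Compound 4 is therefore estimated at 70%, with a range from 55% to 85%.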

Compound 4, a percentage reported as inhibition, at one concentration (the size of the read-out at that concentration, not a potency): 40.3%
Compound 4: middle estimate off by 29.7 percentage points, on the high side; measured number below the stated range.
By their numbers in this assay, from the lowest: compounds 1, 4 and 2 (each within the scatter of the next, the first and the last beyond it); then compound 3.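

A bromo on this aromatic carbon, meta to a large group and para to a group of 9 heavy atoms, gives a number 22.8 percentage points lower from compound 3 to compound 4 (beyond the scatter) and so undoes the gain seen on the other ring. The same exchange of hydrogen for bromo gave a number 13.6 percentage points higher from compound 2 to compound 3 (beyond the scatter) there, so in these two steps the direction of the change depends on the ring that carries it. No measurement here accounts for the fall.

As far as these compounds go, whether a fluoro, a methoxy or an amine on this same carbon would also lower the number remains open.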